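Chloro in Place of Fluoro, Tried on a Second Core

A few compounds are considered here, and "the series" means these few. Any claim that something is new, unique, unknown or untested is made for them only; others in the source may bear on it.

Measured so far:
compound 1 `Fc1ccc2[nH]c(-c3cn(-c4ccccc4)nc3-c3ccccc3)nc2c1` — 2430 nM
compound 2 `Clc1ccc2[nH]c(-c3cn(-c4ccccc4)nc3-c3ccccc3)nc2c1` — 1960 nM
compound 3 `Fc1ccc(-c2nn(-c3ccccc3)cc2-c2nc3ccccc3[nH]2)cc1` — 3200 nM

All three values come from a functional assay on MCF7 cells (Homo sapiens) for antiproliferative activity, read by MTT assay, with a stated time of 48 h; on this read-out higher numbers stand for weaker inhibition and lower numbers for stronger inhibition. Compound 4 `Clc1ccc(-c2nn(-c3ccccc3)cc2-c2nc3ccccc3[nH]2)cc1` has not been measured. It differs from compound 3 in one place: chloro in place of fluoro on an aromatic carbon. The same kind of change was already made from compound 1 to compound 2: chloro in place of fluoro on an aromatic carbon, which gave a 1.2-fold lower number from compound 1 to compound 2 (0.09 log units; within the scatter). The surroundings are not identical: in compound 1 the ring is part of a fused system, with the change meta to a fused ring and para to a fused ring, whereas in compound 3 it sits para to a large group. Compound 3 and compound 1 share the same atoms joined differently, and the difference between the two cores is not broken down here. Resting on a 1.2-fold lower number from compound 1 to compound 2 (0.09 log units; within the scatter), the step from compound 3 to compound 4 is expected to be a 1.2-fold lower number from compound 3 to compound 4 (0.07 log units; within the scatter). For compound 4 the estimate in this assay is 2700 nM, between 1300 nM and 5500 nM.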

Compound 4, half-maximal inhibitory concentration: 3030 nM
Estimate against measurement, compound 4: 1.1-fold (0.05 log units) below; measured number inside the range.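

On the second core, chloro in place of fluoro gave a 1.1-fold lower number from compound 3 to compound 4 (0.02 log units; within the scatter), a step too small to tell apart from repeat-measurement noise. Set beside the first core, the two steps agree: the same change on two cores in this assay, a 1.2-fold lower number (0.09 log units; within the scatter) from compound 1 to compound 2 and a 1.1-fold lower number (0.02 log units; within the scatter) from compound 3 to compound 4, 1.2-fold (0.07 log units) apart, within the scatter of two such steps

So the swap did little on either core, but that does not show a real difference between chloro and fluoro, nor that a change with a larger effect would carry across these cores in the same way.

Both swaps trade one halogen for another, which leaves open whether a different kind of group on that ring, such as an amine, a methoxy group or a carboxylic acid, would move the number beyond the scatter. Going by these compounds, it also remains open whether such a group would behave alike on both cores.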